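The source may hold more compounds than are shown below. What is called first, only, known or untested is meant among the compounds shown, and "the series" means these compounds.

Compound 1 `CCSc1nn2cc(-c3cc4ccccc4o3)nc2s1`: 2900 nM
Compound 2 `COc1cc(OCc2cccc(Sc3ccccc3)c2)c2cc(-c3cn4nc(OC)sc4n3)oc2c1`: 0.89 nM

Within the data shown here, in a functional assay on HEK293 cells for antagonist activity at proteinase-activated receptor 4 (Homo sapiens), read by FLIPR and calcium flux, with a stated time of 30 min (on this read-out higher numbers stand for weaker inhibition and lower numbers for stronger inhibition), compound 1 gives 2900 nM, the highest of the two numbers recorded; the only other measured compound, compound 2, gives 0.89 nM, and that gap lies far beyond the scatter. Among the measured compounds shown here, no two measured compounds differ in a single place, so no measured step offers guidance. Compound 3 `Cc1nn2cc(-c3cc4ccccc4o3)nc2s1` differs from compound 1 in one spot: methyl in place of ethylsulfanyl on an aromatic carbon. Nothing measured here speaks to this exchange on its own. For the measured compounds named here, with methyl in place of ethylsulfanyl and no comparable step to lean on, compound 3 is expected to land near compound 1, with a slight drift toward weaker inhibition rather than a gain. The expected step of a 1.7-fold higher number from compound 1 to compound 3 (0.24 log units; within the scatter) is therefore small. Compound 3 is estimated at 5000 nM, within a range of 1500 nM to 20000 nM.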

Compound 3, half-maximal inhibitory concentration: 37 nM
The estimate for compound 3 lay 140-fold (2.13 log units) above the measured number; measured number below the stated range.
By their numbers in this assay, from the lowest: compound 2; then compound 3; then compound 1.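

In this assay, exchanging ethylsulfanyl for methyl on this aromatic carbon, next to the ring sulfur and the ring nitrogen, gives a 78-fold lower number from compound 1 to compound 3 (1.89 log units; beyond the scatter), a large step beyond the scatter. Among these compounds, this is the first single-place comparison, and it shows that the group at this position alone can move the read-out strongly on the shared core, with methyl giving the stronger inhibition of the two groups. Nothing available here offers an explanation for the size of this step.

With only these two groups compared, the compounds shown leave open whether the step follows from losing the sulfur or from shortening the chain. From the compounds shown here alone, an ethyl or a methylsulfanyl group at this position would separate those two readings, and the effect of an amine there also remains open.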